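The source may report more compounds than this note shows. Statements on the series, on what has been measured and on what is new or still open speak of the compounds shown alone.

Measured so far:
- compound 1 `Cc1cc(OCc2ccccc2)c2nc(C)c(C)n2c1` — 86%
- compound 2 `CC(C)c1nc2c(OCc3ccccc3)cccn2c1N` — 0%
- compound 3 `Cc1nc2c(Oc3ccccc3)cccn2c1N` — 34%

In a functional assay on the whole organism with Rattus norvegicus as the target, at a dose of 40 mg/kg by the intraperitoneal route (on this read-out lower numbers stand for less inhibition and higher numbers for more inhibition at the one dose given (going by the name of the read-out)), compound 1 gives 86%, the highest of the three numbers. Compound 3 comes nearest with 34%, a gap beyond the scatter; compound 2 lies furthest with 0%, also beyond the scatter. For the measured compounds named here, no pair of measured compounds differs in one place only, so no single step can be read off.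

Compound 4 `Cc1cc(OCc2ccccc2)c2nc(C)c(N)n2c1` is the next compound, not yet measured. It differs from compound 1 by amino in place of methyl on an aromatic carbon. The two lower numbers, compound 2 with 0% and compound 3 with 34%, belong to compounds carrying an amino group on such a ring carbon, though each differs from compound 1 in further places. A downward step is therefore expected, a number 46 percentage points lower from compound 1 to compound 4 (beyond the scatter), with wide uncertainty. Compound 4 is estimated at 40%, within 10% to 75%.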

Compound 4, a percentage reported as inhibition, in the whole organism at one dose (the size of the read-out at that dose, not a potency): 65%
Estimate against measurement, compound 4: 25 percentage points below; the range from low to high includes it.
By their numbers in this assay, from the lowest: compound 2; then compound 3; then compound 4; then compound 1.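

In this assay, amino in place of methyl on this aromatic carbon of the five-membered ring gives a number 21 percentage points lower from compound 1 to compound 4 (beyond the scatter). The position therefore accepts the amino group with a modest loss, and compound 4 still reaches 65%, while steps to compound 2 and compound 3 cannot be read. Nothing at hand bears on what lies behind this step.

Still open, on these data alone, is how a methylamino group, a dimethylamino group or a hydroxyl on the same carbon would compare with amino and methyl. Also open, as far as these compounds go, is whether a longer chain there, such as ethyl or propyl, would keep the number near that of compound 1.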